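Fluorophenyl to pyridyl swap, compound 3 to compound 4

A few compounds are considered here, and "the series" means these few. Any claim that something is new, unique, unknown or untested is made for them only; others in the source may bear on it.

Compound 3 `O=C(C(Nc1ccccc1F)c1ccc(C(F)(F)F)cc1)N1CCCC1c1cccc(F)c1` gives the lowest number of the three measured in an assay on HEK293 cells for antagonist activity at transient receptor potential M8 protein (Canis lupus familiaris), read by fluorescence and calcium flux, with a stated time of 5 min (on this read-out lower numbers stand for stronger inhibition and higher numbers for weaker inhibition), at 9 nM. Compound 2 `O=C(C(Nc1ccccc1)c1ccc(C(F)(F)F)cc1)N1CCCC1c1ccccc1F` stands nearest with 30 nM, and compound 1 `O=C(C(Nc1ccccc1)c1ccc(C(F)(F)F)cc1)N1CCCC1c1ccccc1` furthest with 60 nM; both gaps to compound 3 lie beyond the scatter. Compound 4 `O=C(C(Nc1ccccc1F)c1ccc(C(F)(F)F)cc1)N1CCCC1c1cccnc1` differs from compound 3 by pyridin-3-yl in place of 3-fluorophenyl on a saturated ring carbon. Within the data shown here, no measured step replaces one aromatic ring by another; the only single-point step, a 2.0-fold lower number from compound 1 to compound 2 (0.30 log units; within the scatter), concerns a fluorine on an aromatic carbon and is within the scatter. The change here takes away the fluorine and brings in a ring nitrogen at once, and the direction is uncertain. For compound 4 a weakening within or just beyond the scatter is expected, a 2.2-fold higher number from compound 3 to compound 4 (0.35 log units; beyond the scatter). Compound 4 is therefore estimated at 20 nM, with a range of 6 nM to 60 nM.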

Compound 4, half-maximal inhibitory concentration: 7 nM
The estimate for compound 4 lay 2.9-fold (0.46 log units) above the measured number; measured number inside the range.
By their numbers in this assay, from the lowest: compounds 4 and 3 (each within the scatter of the next); then compounds 2 and 1 (each within the scatter of the next).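

In this assay, among these compounds, replacing the aromatic ring on the saturated ring carbon gives a 1.3-fold lower number from compound 3 to compound 4 (0.11 log units; within the scatter) and is the first measured step of this kind. This position therefore accepts pyridin-3-yl in place of 3-fluorophenyl, losing the fluorine and gaining a ring nitrogen, with no change beyond the scatter. Nothing available explains why the two rings read alike.

On these data alone, whether pyridin-2-yl or pyridin-4-yl would read the same at this carbon remains open. So does whether a saturated ring such as piperidine, or a simple methyl group, could stand there.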